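This account rests on a few compounds, and the source may have more. Where it says the series, first, only, none or still open, it means among the compounds named here.

Working notes on the series. Among the compounds with values here, compound 1 `COc1cccc([C@@H](CO)O[C@H]2CCCN(Cc3ccc(C(=O)O)cc3C)[C@H]2c2ccccc2)c1` and compound 2 `O=C(O)C12CC(CN3CCC[C@H](O[C@H](CO)c4cc(Cl)cc(Cl)c4)[C@@H]3c3ccccc3)(C1)C2` share a core and differ in two places at once, so no single step between them can be read. In an assay on isolated protein for activation of cGMP-dependent protein kinase 1 (Homo sapiens), read by ADP-Glo, with stated times of 30 min and 2 h, in the presence of a further agent that is not named here (a higher number here means that more compound is needed for the effect, a lower number that less compound is needed), compound 1 gives 81000 nM, while compound 2 gives 12000 nM, the lowest of the two numbers, the gap to compound 1 lying beyond the scatter.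

Compound 3 `COC(=O)c1ccc(CN2CCC[C@H](O[C@H](CO)c3cc(Cl)cc(Cl)c3)[C@@H]2c2ccccc2)c(C)c1` is not yet measured. From compound 2 it differs by a group of 11 heavy atoms (9 carbon, 2 oxygen; one six-membered aromatic ring of carbon only) in place of a group of 8 heavy atoms (6 carbon, 2 oxygen; 2 four-membered non-aromatic rings of carbon only), on a saturated chain carbon bound to an amine nitrogen in a ring. Within the data shown here, no measured pair shows this change, so the direction is open; a step of moderate size upward is expected, from compound 2 to compound 3 estimated as a 2.5-fold higher number from compound 2 to compound 3 (0.40 log units; beyond the scatter). For compound 3 the expected value in this assay is 30000 nM, within 6000 nM to 150000 nM.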

Compound 3, half-maximal effective concentration: 900 nM
The estimate for compound 3 lay 33-fold (1.52 log units) above the measured number; the measured number lies below the stated range.
By their numbers in this assay, from the lowest: compound 3; then compound 2; then compound 1.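

Within the data shown here, at the place on a saturated chain carbon bound to an amine nitrogen in a ring, this exchange gives the first readable single change: in this assay, a 13-fold lower number from compound 2 to compound 3 (1.12 log units; beyond the scatter). The number therefore responds strongly to the group held here, and the one six-membered aromatic ring of carbon only, with 0 hydrogen-bond donors, is accepted. Nothing measured here gives a reason for this step.

As far as these compounds go, the exchange alters the rings and the donor count together, so their separate shares remain open. Also open, from the compounds shown here alone, is how a carboxylic acid or an amide on the same aromatic ring would compare with compound 3, as the gap to compound 1 spans two places and cannot be read.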